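Chain-terminus variation on the allyl-acetophenone series

This account rests on a few compounds, and the source may have more. Where it says the series, first, only, none or still open, it means among the compounds named here.

Measured compounds: compound 1 `C=CCc1cc(C(C)=O)c(O)cc1OCCCCCCC#N`, compound 2 `C=CCc1cc(C(C)=O)c(O)cc1OCCCC`, compound 3 `C=CCc1cc(C(C)=O)c(O)cc1OCCCCCC(C)=O`. In an assay on isolated protein for inhibition of leukotriene B4 receptor 1 (Homo sapiens), tested at 10 uM (on this read-out lower numbers stand for less inhibition and higher numbers for more inhibition at the one concentration tested (going by the name of the read-out)), compound 1 gives 97%, compound 2 gives 32% and compound 3 gives 98%.

Compound 3 holds the highest number of the three, with compound 1 within the scatter of it and compound 2 far below, the steps being a number 1 percentage points higher from compound 1 to compound 3 (within the scatter) and a number 66 percentage points higher from compound 2 to compound 3 (beyond the scatter).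

Compound 4 `C=CCc1cc(C(C)=O)c(O)cc1OCCCCCC(=O)NO` differs from compound 3 by hydroxyamino in place of methyl on a carbonyl carbon. The step of a number 1 percentage points higher from compound 1 to compound 3 (within the scatter) shows that swapping one terminal group for another at the chain end leaves the read-out unchanged, while a number 66 percentage points higher from compound 2 to compound 3 (beyond the scatter) shows the terminus matters. A step of no more than scatter size is therefore expected, a number 8 percentage points lower from compound 3 to compound 4 (within the scatter), and compound 4 is estimated at 90%, between 70% and 100%.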

Compound 4, a percentage reported as inhibition, at one concentration (the size of the read-out at that concentration, not a potency): 85%
Compound 4: middle estimate off by 5 percentage points, on the high side; low and high end bracket the measured number.
By their numbers in this assay, from the lowest: compound 2; then compound 4; then compounds 1 and 3 (each within the scatter of the next).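

The step of a number 13 percentage points lower from compound 3 to compound 4 (beyond the scatter) in this assay and the step of a number 12 percentage points lower from compound 1 to compound 4 (beyond the scatter) show that the chain end is less interchangeable than compound 1 and compound 3 suggested, since hydroxyamino on the carbonyl carbon gives a modest loss. The step of a number 53 percentage points higher from compound 2 to compound 4 (beyond the scatter) shows that a large gain over the unsubstituted chain remains. No measured evidence accounts for these steps. As far as these compounds go, whether a carboxylic acid or a primary amide at this chain end would match compound 3 or compound 4 remains open. So does the effect of a longer chain carrying hydroxycarbamoyl.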